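A few compounds are considered here, and "the series" means these few. Any claim that something is new, unique, unknown or untested is made for them only; others in the source may bear on it.

Compound 1, `CCCCCCCCc1ccc(OCC(=O)Cn2nnc(C(=O)O)n2)cc1`, in an assay on microsomes from brain for inhibition of Fatty-acid amide hydrolase 1 (Rattus norvegicus), read by fluorescence and HPLC, with a stated time of 60 min; on this read-out higher numbers stand for weaker inhibition and lower numbers for stronger inhibition: 41 nM
Compound 2, `CCCCCCCCc1ccc(OCC(=O)Cn2nnc(C(=O)OC)n2)cc1`: 88 nM
Compound 3, `CCCCCCCCc1ccc(OCC(=O)Cn2nnnc2SC)cc1`: 22 nM

The three compounds share the core of compound 1 and differ only at the tetrazole. Exchanging the acid for its methyl ester gives a 2.1-fold higher number from compound 1 to compound 2 (0.33 log units; beyond the scatter). Moving to the methylsulfanyl tetrazole gives a 1.9-fold lower number from compound 1 to compound 3 (0.27 log units; within the scatter) and a 4.0-fold lower number from compound 2 to compound 3 (0.60 log units; beyond the scatter). Compound 3 thus shows the lowest of the three numbers, though its gap to compound 1 lies within the scatter, so the two cannot be ordered.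

Compound 4, `CCCCCCCCc1ccc(OCC(=O)Cn2nnnc2-c2ccc(Cl)cc2)cc1`, carries the change (4-chlorophenyl in place of methylsulfanyl on an aromatic carbon). For the measured compounds named here, none of the measured steps tests this kind of exchange: the steps from compound 1 and compound 2 to compound 3 replaced the tetrazole substituent together with its point of attachment, whereas here only the group on the ring carbon changes. Going by the values given here, the measured steps were all modest or within the scatter, so no large step in this assay is expected in either direction. Compound 4 is therefore estimated at 30 nM, between 8 nM and 120 nM, which would mean an expected step of a 1.4-fold higher number from compound 3 to compound 4 (0.13 log units; within the scatter).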

Compound 4, half-maximal inhibitory concentration: 130 nM
For compound 4 the middle estimate is 4.3-fold (0.64 log units) below the measured one, and the stated range ends below it.
By their numbers in this assay, from the lowest: compounds 3 and 1 (each within the scatter of the next); then compounds 2 and 4 (each within the scatter of the next).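

In this assay, 4-chlorophenyl in place of methylsulfanyl gives a 5.9-fold higher number from compound 3 to compound 4 (0.77 log units; beyond the scatter), and this is the first step shown that changes only the group on the aromatic carbon of the five-membered aromatic ring with 4 nitrogen. The step is modest but beyond the scatter, so inhibition at this position does depend on the group it carries, and here the group with one six-membered aromatic ring of carbon only goes with weaker inhibition. Nothing measured here accounts for this step.

The compounds shown leave open whether the higher number goes with the aromatic ring itself or with its chlorine, a question an unsubstituted phenyl would address. They also leave open how a methyl group or an amine on the same carbon would compare with methylsulfanyl.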